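Working notes: closing the side chain into a ring

The source may report more compounds than this note shows. Statements on the series, on what has been measured and on what is new or still open speak of the compounds shown alone.

The series shares one core; compound 1 `CCCCN(C1=NCCN1)c1c(Br)cccc1Br` carries a propyl group on the saturated chain carbon bound to the nitrogen on the aromatic ring. In a physicochemical assay for acid dissociation, compound 1 gives 11, the second highest of the three numbers measured. Compound 2 `C=C(C)CN(C1=NCCN1)c1c(Br)cccc1Br` gives 10.7 and compound 3 `C=CCCN(C1=NCCN1)c1c(Br)cccc1Br` gives 11.2. The steps among these three all alter the same chain: a number 0.30 log units lower from compound 1 to compound 2 (within the scatter), a number 0.20 log units higher from compound 1 to compound 3 (within the scatter), and a number 0.50 log units higher from compound 2 to compound 3 (beyond the scatter), the last being the only one beyond the scatter, and a modest one.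

Compound 4 `Brc1cccc(Br)c1N(CC1CCC1)C1=NCCN1` has not been measured. Its difference from compound 1 is cyclobutyl in place of propyl on a saturated chain carbon bound to a nitrogen on an aromatic ring. Among the measured compounds shown here, no measured step matches this change, so what bears on it is only the general behaviour of the chain: two of the three steps on it sit within the scatter, and the one that does not is modest. The expectation is therefore a step of no more than the scatter, neither clearly toward a higher nor toward a lower read-out, and the estimate for compound 4 is 11, with a range from 10.6 to 11.4. Against compound 1 this estimate means no change at the digits printed from compound 1 to compound 4 (within the scatter), which is expected to fall within the usual scatter.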

Compound 4, acid dissociation constant: 10.9
Beside the measured number, compound 4's estimate is 0.10 log units above it; the range from low to high includes it.
By their numbers in this assay, from the lowest: compounds 2, 4, 1 and 3 (each within the scatter of the next, the first and the last beyond it).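

In this assay, the first ring at this place gives a reading close to that of the open chain: cyclobutyl in place of propyl on a saturated chain carbon bound to a nitrogen on an aromatic ring gives a number 0.10 log units lower from compound 1 to compound 4 (within the scatter), so closing the side chain into a four-membered carbon ring does not move the read-out beyond the scatter. The comparisons with the two unsaturated chains agree, with a number 0.30 log units lower from compound 3 to compound 4 (within the scatter) and a number 0.20 log units higher from compound 2 to compound 4 (within the scatter), which places compound 4 within the scatter of all three open-chain compounds, even though those two chains are themselves separated by a number 0.50 log units higher from compound 2 to compound 3 (beyond the scatter). Nothing available accounts for the reading of compound 4 or for the small size of these steps.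

The single ring shown leaves open whether a cyclopropyl or cyclohexyl ring at the same place would also stay within the scatter of compound 1. Going by these compounds, it is equally open whether a chain ending in an amine or a carboxylic acid, which would bring a heteroatom to this position, would shift the number further than any all-carbon group has so far.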